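The source may report more compounds than this note shows. Statements on the series, on what has been measured and on what is new or still open speak of the compounds shown alone.

Compounds measured in a functional assay on A549 cells (Homo sapiens) for cytotoxicity, read by sulforhodamine B assay, with a stated time of 48 h; a higher number here means a weaker inhibitor, a lower number a stronger inhibitor:

- Compound 1 `COc1cc(/C=C/C(=O)c2ccc(N)c(-c3ccc(F)cc3)c2)cc(Br)c1O`: > 50000 nM, a limit of the assay
- Compound 2 `COc1ccc(/C=C/C(=O)c2ccc(NC(C)=O)c(-c3ccc(F)cc3)c2)cc1OC`: 7380 nM
- Compound 3 `O=C(/C=C/c1ccc(Br)cc1)c1cccc(-c2cccc(F)c2)c1`: 19800 nM

Only compound 2 and compound 3 have actual numbers. Compound 3, at 19800 nM, holds the higher of the two, and the gap to compound 2 lies beyond the scatter. Compound 4 `COc1ccccc1/C=C/C(=O)c1cccc(-c2cccc(F)c2)c1` carries 2-methoxyphenyl in place of 4-bromophenyl on a double-bonded chain carbon bound to a double-bonded chain carbon. For the measured compounds named here, no measured pair shows what such a change does in this assay, so no shift beyond the scatter is expected. The expected step is a 1.3-fold lower number from compound 3 to compound 4 (0.12 log units; within the scatter), a slight strengthening at most. For compound 4 the estimated value is 15000 nM, with an expected range of 5000 nM to 45000 nM.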

Compound 4, half-maximal inhibitory concentration: 15500 nM
Estimate against measurement, compound 4: 1.0-fold (0.01 log units) below; the measured number falls inside the stated range.
By their numbers in this assay, from the lowest: compound 2; then compounds 4 and 3 (each within the scatter of the next). At a limit, above all of these: compound 1.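

Replacing 4-bromophenyl with 2-methoxyphenyl on a double-bonded chain carbon bound to a double-bonded chain carbon gives a 1.3-fold lower number from compound 3 to compound 4 (0.11 log units; within the scatter) in this assay. For the compounds shown here, this is the first pair in the set that differs in one place, and it shows that at this position the two substituted rings cannot be told apart in this assay. No measurement shown bears on why the two compounds read alike.

As far as these compounds go, whether an unsubstituted phenyl, or a ring carrying an amine or a carboxylic acid, would read differently at this place stays open. So does whether this swap behaves the same way on the core of compound 2.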